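Two Dichlorophenyl Patterns Tested for HeLa Cytotoxicity

The source may report more compounds than this note shows. Statements on the series, on what has been measured and on what is new or still open speak of the compounds shown alone.

Measured so far in a functional assay on HeLa cells (Homo sapiens) for cytotoxicity, read by MTT assay, with a stated time of 24 h; on this read-out lower numbers stand for stronger inhibition and higher numbers for weaker inhibition:
Compound 1, `COc1cc(/C=C2\CN(C)C/C(=C\c3ccc(Cl)cc3Cl)C2=O)cc(OC)c1OC`, a limit of the assay rather than a number: > 20000 nM
Compound 2, `COc1cc(/C=C2\CN(C)C/C(=C\c3ccc(Cl)c(Cl)c3)C2=O)cc(OC)c1OC`: 13500 nM
Compound 3, `CN1C/C(=C\c2cccc([N+](=O)[O-])c2)C(=O)/C(=C/c2ccc(Cl)cc2Cl)C1`: 8900 nM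

Compound 1 reports only a limit in this assay. Compound 2 carries 3,4-dichlorophenyl in place of 2,4-dichlorophenyl on a double-bonded chain carbon bound to a double-bonded ring carbon, and this change gave an at least 1.4-fold lower number from compound 1 to compound 2 (0.17 log units; that floor lies within the scatter), a floor set by the limit (the limit of > 20000 nM in this assay, at which 1 of the 3 values shown sits). Compound 3 and compound 2 lie within the scatter of each other, so no order between them is claimed. The difference between the core of compound 3 and the core of compound 1 is not broken down here.

Compound 4, `CN1C/C(=C\c2cccc([N+](=O)[O-])c2)C(=O)/C(=C/c2ccc(Cl)c(Cl)c2)C1`, is not yet measured. It differs from compound 3 by 3,4-dichlorophenyl in place of 2,4-dichlorophenyl on a double-bonded chain carbon bound to a double-bonded ring carbon, the same change as that from compound 1 to compound 2. For compound 4 the expected step is a 1.4-fold lower number from compound 3 to compound 4 (0.14 log units; within the scatter), resting on the measured at least 1.4-fold lower number from compound 1 to compound 2 (0.17 log units; that floor lies within the scatter), which only sets a floor within the scatter. Compound 4 is therefore estimated at 6500 nM, between 3000 nM and 15000 nM.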

Compound 4, half-maximal inhibitory concentration: 9120 nM
Estimate against measurement, compound 4: 1.4-fold (0.15 log units) below; measured number inside the range.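

In this assay, replacing 2,4-dichlorophenyl with 3,4-dichlorophenyl gave a 1.0-fold higher number from compound 3 to compound 4 (0.01 log units; within the scatter), so on this core the change produced no difference that can be told from the scatter. Set beside the earlier step, the result reads: the same change on two cores in this assay, an at least 1.4-fold lower number (0.17 log units; that floor lies within the scatter) from compound 1 to compound 2 and a 1.0-fold higher number (0.01 log units; within the scatter) from compound 3 to compound 4; the limit leaves it open whether they differ. The earlier step rests on a limit for compound 1, so the two steps show neither that the change carries over from one core to the other nor that it fails to.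

The compounds shown leave open how either dichlorophenyl pattern compares with a phenyl ring bearing a trifluoromethyl group or a single fluorine. They also leave open whether the step would look the same on a core carrying a carboxylic acid.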